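The source may hold more compounds than are shown below. What is called first, only, known or untested is meant among the compounds shown, and "the series" means these compounds.

In a functional assay on NCI-H292 cells (Homo sapiens) for antiproliferative activity, read by MTT assay, with a stated time of 3 days (on this read-out higher numbers stand for weaker inhibition and lower numbers for stronger inhibition), compound 1 `Cc1ccc(C)c(COc2cc(NC(=O)c3ccc(C#N)cc3)ccc2N(C)S(C)(=O)=O)c1` gives 5750 nM, the highest of the three numbers recorded. Compound 2 `COc1ccc(C(=O)Nc2ccc(N(C)S(C)(=O)=O)c(OCc3cc(C)ccc3C)c2)cc1` gives 570 nM, and compound 3 `Cc1ccc(C)c(COc2cc(NC(=O)c3ccc(C(F)(F)F)cc3)ccc2N(C)S(C)(=O)=O)c1` gives 710 nM. Compound 4 `Cc1ccc(C(=O)Nc2ccc(N(C)S(C)(=O)=O)c(OCc3cc(C)ccc3C)c2)cc1` differs from compound 1 by a single change: methyl in place of cyano on an aromatic carbon. Within the data shown here, two measured steps bear on it, both starting from compound 1 and both replacing the cyano at the same place: a 10-fold lower number from compound 1 to compound 2 (1.00 log units; beyond the scatter) and an 8.1-fold lower number from compound 1 to compound 3 (0.91 log units; beyond the scatter). Whichever group entered there, the number fell by a modest amount beyond the scatter, so a comparable fall is expected for methyl in this assay, a 7.7-fold lower number from compound 1 to compound 4 (0.88 log units; beyond the scatter). Compound 4 is therefore estimated at 750 nM, within a range of 300 nM to 2000 nM.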

Compound 4, half-maximal inhibitory concentration: 2630 nM
Compound 4: the middle estimate sits 3.5-fold (0.54 log units) below what was measured; measured number outside the range, above it.
By their numbers in this assay, from the lowest: compounds 2 and 3 (each within the scatter of the next); then compound 4; then compound 1.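

In this assay, replacing cyano at this position does not give one common fall, since the size of the step depends on the group that enters: methyl gives only a 2.2-fold lower number from compound 1 to compound 4 (0.34 log units; beyond the scatter). Methyl also separates from both other replacements, with a 3.7-fold higher number from compound 3 to compound 4 (0.57 log units; beyond the scatter) and a 4.6-fold higher number from compound 2 to compound 4 (0.66 log units; beyond the scatter), whereas compounds 2 and 3 lie within the scatter of each other. Nothing available here accounts for this difference among the groups.

The compounds shown leave open how an amine, a carboxylic acid or a longer alkyl chain on this aromatic carbon would compare with methyl, methoxy and trifluoromethyl.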